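The source may report more compounds than this note shows. Statements on the series, on what has been measured and on what is new or still open speak of the compounds shown alone.

In a functional assay on HeLa cells (Homo sapiens) for inhibition, read by MTT assay, with a stated time of 48 h (a lower number here means a stronger inhibitor of growth, a higher number a weaker inhibitor of growth), the three measured compounds gave these numbers:

Compound 1 `Cn1cc(C2CC(c3ccccc3)=NN2C(=O)c2cccnc2)c2cc(Br)ccc21`: 1730 nM
Compound 2 `COc1ccc(C2=NN(C(=O)c3cccnc3)C(c3cn(C)c4ccc(Br)cc34)C2)cc1`: 890 nM
Compound 3 `COc1ccc2c(c1)c(C1CC(c3ccccc3)=NN1C(=O)c1cccnc1)cn2C`: 3590 nM

Compound 4 `COc1cccc(C2=NN(C(=O)c3cccnc3)C(c3cn(C)c4ccc(OC)cc34)C2)c1` has not yet been measured in this assay.

Compound 2 is made from compound 1 by one change, (methoxy in place of hydrogen on an aromatic carbon). The result was a 1.9-fold lower number from compound 1 to compound 2 (0.29 log units; within the scatter), so the two numbers cannot be told apart with confidence.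

Compound 4 is related to compound 3 by a change of the same kind, (methoxy in place of hydrogen on an aromatic carbon). It is not the same change, though: in compound 2 the methoxy sits para to a large group, while in compound 4 it sits meta to a large group. The cores of the two pairs also differ. Compound 3 differs from compound 1 by methoxy in place of bromo on an aromatic carbon, and that change gave a 2.1-fold higher number from compound 1 to compound 3 (0.32 log units; beyond the scatter), a modest step beyond the scatter that leaves compound 3 with the highest number of the three.

For compound 4 the expected step from compound 3 is a 1.3-fold lower number from compound 3 to compound 4 (0.11 log units; within the scatter). That expectation rests on the earlier step of a 1.9-fold lower number from compound 1 to compound 2 (0.29 log units; within the scatter), which stayed within the scatter, and on the fact that a methoxy at a meta position has no measured precedent among these compounds, so the range is kept wide. Compound 4 is thus expected to give 2800 nM in this assay, with an estimated range from 1000 nM to 8000 nM.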

Compound 4, concentration for 50% growth inhibition: 1270 nM
For compound 4 the middle estimate is 2.2-fold (0.34 log units) above the measured one, and the stated range covers the measured number.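

In this assay, changing phenyl to 3-methoxyphenyl, with the methoxy meta to a large group, gives a 2.8-fold lower number from compound 3 to compound 4 (0.45 log units; beyond the scatter), a modest step that stands clear of the usual scatter. Both steps run in the same direction, and their sizes cannot be told apart: the same change on two cores in this assay, a 1.9-fold lower number (0.29 log units; within the scatter) from compound 1 to compound 2 and a 2.8-fold lower number (0.45 log units; beyond the scatter) from compound 3 to compound 4, 1.5-fold (0.16 log units) apart, within the scatter of two such steps. For the compounds shown here, this fits the idea that adding a methoxy to this phenyl ring carries over from the core of compound 1 to the core of compound 3, but it rests on only two pairs, the earlier step alone lies within the scatter, and the methoxy sits at a different position in each pair, so it does not show that position is unimportant or that the result would hold on any other core.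

The compounds shown leave open how the two methoxy positions would compare on one and the same core, which would separate the effect of position from the effect of the core. They also leave open how other groups at these places on the phenyl ring would behave, such as a hydroxyl, an amine or a carboxylic acid.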